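Removing a Nitro Group from Two Related Sulfonamides

A few compounds are considered here, and "the series" means these few. Any claim that something is new, unique, unknown or untested is made for them only; others in the source may bear on it.

Compound 1, `CCC(C)C(C(=O)Nc1ccc(C(C)=O)cc1)N(C(=O)c1ccccc1)S(=O)(=O)c1ccc([N+](=O)[O-])cc1`: 48.4%
Compound 2, `CC(=O)c1ccc(NC(=O)C2CC(O)CN2S(=O)(=O)c2ccc([N+](=O)[O-])cc2)cc1`: 60.1%
Compound 3, `CCC(C)C(C(=O)Nc1ccc(C(C)=O)cc1)N(C(=O)c1ccccc1)S(=O)(=O)c1ccccc1`: 15.5%

Of the compounds shown here, three have been measured in a functional assay for inhibition, read by spectrophotometry, with a stated time of 20 min, tested at 4 mg/mL; on this read-out higher numbers stand for a stronger effect at the one concentration tested and lower numbers for a weaker effect. Compound 2 gives the highest reading, and its lead over compound 1 and compound 3 is in each case beyond the scatter of this assay. The difference between the core of compound 2 and the core of compound 1 is not broken down here. Compound 1 and compound 3 share one core and differ in a single place: hydrogen in place of nitro on an aromatic carbon. That change made a large step, a number 32.9 percentage points lower from compound 1 to compound 3 (beyond the scatter).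

Compound 4, `CC(=O)c1ccc(NC(=O)C2CC(O)CN2S(=O)(=O)c2ccccc2)cc1`, has not yet been measured. It stands to compound 2 exactly as compound 3 stands to compound 1, with the same change in the same place: hydrogen in place of nitro on an aromatic carbon. For the measured compounds named here, since the only comparison available is the one from compound 1 to compound 3, the expectation for compound 4 rests on that single step, and on the assumption that the change acts alike on the two cores, which cannot be checked here. The step from compound 2 to compound 4 is therefore expected to be of similar size, a number 33.1 percentage points lower from compound 2 to compound 4 (beyond the scatter), because a number 32.9 percentage points lower from compound 1 to compound 3 (beyond the scatter) was a large drop. Compound 4 is estimated at 27%, with a range from 10% to 45%.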

Compound 4, a percentage reported as inhibition, at one concentration (the size of the read-out at that concentration, not a potency): 54.5%
For compound 4 the middle estimate is 27.5 percentage points below the measured one, and the stated range ends below it.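

On the second core, the swap of nitro for hydrogen reads a number 5.6 percentage points lower from compound 2 to compound 4 (within the scatter) in this assay, so the two readings on that core cannot be told apart. The swap therefore does not carry over in size from one core to the other: the same change on two cores in this assay, a number 32.9 percentage points lower (beyond the scatter) from compound 1 to compound 3 and a number 5.6 percentage points lower (within the scatter) from compound 2 to compound 4, 27.3 percentage points apart, beyond the scatter of two such steps

This shows that the large drop seen on the first core cannot be taken as a rule for this series, but it does not show why the two cores behave differently, and two pairs of compounds cannot predict the result on a third core.

The compounds shown carry only nitro or hydrogen in this place, so it remains open how an amine, a carboxylic acid or a methoxy group there would read on either core. For the compounds shown here, no pair separates the individual differences between the two cores, so it also remains open which of those differences decides whether the swap gives a large step or one within the scatter.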